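This account rests on a few compounds, and the source may have more. Where it says the series, first, only, none or still open, it means among the compounds named here.

Measured in an ADME assay on microsomes from liver (Mus musculus) for metabolic stability, read by LC-MS, with a stated time of 10 min; on this read-out higher numbers stand for a more stable compound and lower numbers for a less stable compound:
- compound 1 `CN(C[C@H]1Cc2c(cccc2N2CCN(c3cccc(C(F)(F)F)c3)CC2)CN1)[C@H]1CCCc2cccnc21`: 72.3%
- compound 2 `CC(C)N(C[C@H]1Cc2c(cccc2N2CCNCC2)CN1)[C@H]1CCCc2cccnc21`: 91%
- compound 3 `CN(C[C@H]1Cc2c(cccc2N2C[C@H]3C[C@@H]2CN3)CN1)[C@H]1CCCc2cccnc21`: 95.9%

Not yet measured: compound 4 `CN(C[C@H]1Cc2c(cccc2N2CCN(c3ccccn3)CC2)CN1)[C@H]1CCCc2cccnc21`.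

Compound 1 stands lowest of the three, with compound 2 and compound 3 both higher beyond the scatter. Compound 4 has pyridin-2-yl in place of 3-(trifluoromethyl)phenyl on an amine nitrogen in a ring. Within the data shown here, no measured pair differs in one place only, so the expectation has no direct support. Compound 2 at 91% and compound 3 at 95.9% lack an aromatic group on that amine nitrogen, but they differ elsewhere too. A small upward move, probably not beyond the scatter, is expected, with an estimated step of a number 5.7 percentage points higher from compound 1 to compound 4 (within the scatter). The estimate for compound 4 is 78%, with an expected range of 62% to 92%.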

Compound 4, percent of the compound remaining: 46.1%
For compound 4 the middle estimate is 31.9 percentage points above the measured one; the whole stated range lies above it.
By their numbers in this assay, from the lowest: compound 4; then compound 1; then compounds 2 and 3 (each within the scatter of the next).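

Pyridin-2-yl in place of 3-(trifluoromethyl)phenyl on the amine nitrogen in a ring gives, in this assay, a step of a number 26.2 percentage points lower from compound 1 to compound 4 (beyond the scatter) in the series' first pair that differs in one place only. The aromatic group at this position therefore carries weight in this read-out, and the two aromatic groups are not interchangeable. No measurement shown accounts for the step.

Still open, on these data alone, is whether the step goes with the ring nitrogen or with the loss of trifluoromethyl. A plain phenyl or a 5-(trifluoromethyl)pyridin-2-yl on the same nitrogen would separate the two.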